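A Tert-Butyl Step Carried From One Core to Another

A few compounds are considered here, and "the series" means these few. Any claim that something is new, unique, unknown or untested is made for them only; others in the source may bear on it.

Compound 1 `NNC(=O)c1cc(-c2ccccc2)nn1Cc1ccccc1`: 440000 nM
Compound 2 `CC(C)(C)c1ccc(Cn2nc(-c3ccccc3)cc2C(=O)NN)cc1`: 66200 nM
Compound 3 `COc1ccc(-c2cc(C(=O)NN)n(Cc3ccccc3)n2)cc1`: 550000 nM

In a functional assay on A549 cells (Homo sapiens) for inhibition, with a stated time of 48 h (on this read-out higher numbers stand for weaker inhibition and lower numbers for stronger inhibition), compound 1 gives 440000 nM, compound 2 gives 66200 nM and compound 3 gives 550000 nM. Compound 2 differs from compound 1 by tert-butyl in place of hydrogen on an aromatic carbon, and that change brings a 6.6-fold lower number from compound 1 to compound 2 (0.82 log units; beyond the scatter). Compound 3 differs from compound 1 by methoxy in place of hydrogen on an aromatic carbon; its value and that of compound 1 lie within the scatter of each other. Compound 4, `COc1ccc(-c2cc(C(=O)NN)n(Cc3ccc(C(C)(C)C)cc3)n2)cc1`, has not yet been measured. Going by the values given here, it differs from compound 3 by tert-butyl in place of hydrogen on an aromatic carbon, the same change in the same place as the one separating compound 1 from compound 2. Because a 6.6-fold lower number from compound 1 to compound 2 (0.82 log units; beyond the scatter) appeared on the core of compound 1, the step expected for compound 4 is a 6.1-fold lower number from compound 3 to compound 4 (0.79 log units; beyond the scatter). Compound 4 is thus estimated at 90000 nM, between 35000 nM and 250000 nM.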

Compound 4, half-maximal inhibitory concentration: 49900 nM
For compound 4 the middle estimate is 1.8-fold (0.26 log units) above the measured one, within the range that was stated.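

In this assay, tert-butyl in place of hydrogen gives an 11-fold lower number from compound 3 to compound 4 (1.04 log units; beyond the scatter), and this step agrees with the one on the core of compound 1: the same change on two cores in this assay, a 6.6-fold lower number (0.82 log units; beyond the scatter) from compound 1 to compound 2 and an 11-fold lower number (1.04 log units; beyond the scatter) from compound 3 to compound 4, 1.7-fold (0.22 log units) apart, within the scatter of two such steps. Methoxy in place of hydrogen gives a 1.3-fold lower number from compound 2 to compound 4 (0.12 log units; within the scatter), and this small step also reads the same whether or not tert-butyl is present: the same change on two cores in this assay, a 1.3-fold higher number (0.10 log units; within the scatter) from compound 1 to compound 3 and a 1.3-fold lower number (0.12 log units; within the scatter) from compound 2 to compound 4, 1.7-fold (0.22 log units) apart, within the scatter of two such steps. The two changes therefore behaved independently across these four compounds, but a single pair of cores shows neither that the tert-butyl step holds on other cores nor why it occurs.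

Going by these compounds, whether the step needs tert-butyl itself remains open, since a methyl group, an amine or a carboxylic acid in its place would be needed to test this.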